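A Single Methyl Added to Compound 2

The source may hold more compounds than are shown below. What is called first, only, known or untested is meant among the compounds shown, and "the series" means these compounds.

Of the compounds shown here, two have been measured so far: compound 1 (`CN(C)CC[C@H](CSc1ccccc1)Nc1ccc(S(=O)(=O)Nc2cccc3cc(N4CCN(Cc5ccccc5-c5ccc(Cl)cc5)CC4)cnc23)cc1[N+](=O)[O-]`) and compound 2 (`CN(C)CC[C@H](CSc1ccccc1)Nc1ccc(S(=O)(=O)Nc2ncnc3c2CCN(C2CCN(Cc4ccccc4-c4ccc(Cl)cc4)CC2)C3)cc1S(=O)(=O)C(F)(F)F`). In a physicochemical assay for solubility, in simulated intestinal fluid (a higher number here means a more soluble compound, a lower number a less soluble compound), compound 1 gives 44000 nM as its reading. Compound 2 gives 64000 nM in this assay and so stands with compound 1, as the two numbers lie within the scatter of each other. For the measured compounds named here, these two compounds differ in more than one place, and no measured pair differs in a single place, so the data offer no measured step as a guide.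

Compound 3 (`CC(c1ccccc1-c1ccc(Cl)cc1)N1CCC(N2CCc3c(ncnc3NS(=O)(=O)c3ccc(N[C@H](CCN(C)C)CSc4ccccc4)c(S(=O)(=O)C(F)(F)F)c3)C2)CC1`) is compound 2 with one change: methyl in place of hydrogen on a saturated chain carbon bound to an amine nitrogen in a ring and an aromatic carbon. Starting from compound 2 at 64000 nM and with no measured step to draw on, no change beyond the scatter is expected in this assay for this edit. The estimated step is a 1.2-fold lower number from compound 2 to compound 3 (0.07 log units; within the scatter) and it is expected to stay within the scatter. The estimate for compound 3 is 55000 nM with 25000 nM to 120000 nM as the expected range.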

Compound 3, solubility: 31000 nM
The estimate for compound 3 lay 1.8-fold (0.25 log units) above the measured number; measured number inside the range.
By their numbers in this assay, from the lowest: compounds 3, 1 and 2 (each within the scatter of the next, the first and the last beyond it).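

For the compounds shown here, the pair of compound 2 and compound 3 supplies the first measured single-place step in this assay: with methyl in place of hydrogen on a saturated chain carbon bound to an amine nitrogen in a ring and an aromatic carbon, the data show a 2.1-fold lower number from compound 2 to compound 3 (0.31 log units; beyond the scatter). This position is therefore not silent in this assay, since an edit of 1 heavy atom, with no ring, no hydrogen-bond donors or acceptors and no net charge, is the only difference between the two structures and goes with a modest step beyond the scatter. No measurement shown here bears on what lies behind this step.

As far as these compounds go, the finding rests on one pair and one reading per compound, so it remains open whether a larger group at this carbon, such as ethyl or a second methyl, would go with a further step in the same direction, or whether a hydroxymethyl group would go with a step of another size or sign. From the compounds shown here alone, it also remains open whether the same methyl, placed at the matching carbon of compound 1, would give a step of similar size on that different core.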